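Urotensin-2 receptor amide series: methyl replaces trifluoromethyl

This account rests on a few compounds, and the source may have more. Where it says the series, first, only, none or still open, it means among the compounds named here.

The parent of the series is compound 1 `O=C(NC1CCN(Cc2ccc(OC3CCNCC3)c(Br)c2)CC1)c1cccs1`, which in an assay on HEK293 cells for displacement of a labelled ligand from Urotensin-2 receptor (Homo sapiens), read by fluorescence, with a stated time of 90 min (a higher number here means a weaker inhibitor, a lower number a stronger inhibitor), gives 130 nM. Compound 2 `O=C(NC1CCN(Cc2ccc(OC3CCNCC3)c(Br)c2)CC1)c1cc2ccccc2s1` carries 1-benzothiophen-2-yl in place of thiophen-2-yl on the carbonyl carbon and gives 63 nM, a step of a 2.1-fold lower number from compound 1 to compound 2 (0.31 log units; beyond the scatter). Compound 3 `O=C(NC1CCN(Cc2ccc(OC3CCNCC3)c(Br)c2)CC1)c1cc2cc(C(F)(F)F)ccc2s1` adds trifluoromethyl in place of hydrogen on an aromatic carbon and gives 100 nM; the step of a 1.6-fold higher number from compound 2 to compound 3 (0.20 log units; within the scatter) is within the scatter. Compound 3 thus sits within the scatter of both compound 1 and compound 2, and the three numbers span a narrow range.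

Compound 4 `Cc1ccc2sc(C(=O)NC3CCN(Cc4ccc(OC5CCNCC5)c(Br)c4)CC3)cc2c1` differs from compound 3 by methyl in place of trifluoromethyl on an aromatic carbon. Going by the values given here, the step that bears on this position is the one from compound 2 to compound 3, where introducing trifluoromethyl at the same aromatic carbon moved the number only within the scatter; the step from compound 1 to compound 2 concerns a different part of the molecule and is only a loose guide. A small substituent at this carbon is therefore not expected to move the number beyond the scatter, so compound 4 is estimated to land close to compound 3, with the expected step being a 1.3-fold lower number from compound 3 to compound 4 (0.10 log units; within the scatter). Compound 4 is accordingly expected to give about 80 nM, with a likely range from 35 nM to 180 nM.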

Compound 4, half-maximal inhibitory concentration: 74 nM
Compound 4: the middle estimate sits 1.1-fold (0.03 log units) above what was measured; measured number inside the range.
By their numbers in this assay, from the lowest: compounds 2, 4, 3 and 1 (each within the scatter of the next, the first and the last beyond it).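

At this aromatic carbon of the six-membered aromatic ring, methyl in place of trifluoromethyl leaves the number in this assay within the scatter (a 1.4-fold lower number from compound 3 to compound 4 (0.13 log units; within the scatter)). Methyl in place of hydrogen at the same carbon is also within the scatter (a 1.2-fold higher number from compound 2 to compound 4 (0.07 log units; within the scatter)), so hydrogen, methyl and trifluoromethyl cannot be told apart here, whereas the earlier compounds compared only hydrogen with trifluoromethyl. Against the thiophen-2-yl parent, the 5-methyl-1-benzothiophen-2-yl amide stays within the scatter (a 1.8-fold lower number from compound 1 to compound 4 (0.24 log units; within the scatter)), while the unsubstituted 1-benzothiophen-2-yl amide lies just beyond it (a 2.1-fold lower number from compound 1 to compound 2 (0.31 log units; beyond the scatter)), so only the latter separates from compound 1 in this assay.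

Nothing on hand accounts for this tolerance at the aromatic carbon. Still open, as far as these compounds go, is whether an amine, a carboxylic acid or a longer alkyl chain at this carbon would also stay within the scatter, and whether methyl on the other carbons of this ring would behave the same way.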